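Methoxy pattern on the aryl imine of the series

The compounds below may be only part of what the source reports. "The series", "measured", "known", "first", "only" and "open" are said of these compounds alone.

Compound 1 `COc1ccc(/C=N/c2c(C)n(C)n(-c3ccccc3)c2=O)cc1` and compound 2 `COc1cccc(/C=N/c2c(C)n(C)n(-c3ccccc3)c2=O)c1` share one core and differ only in the aromatic ring on the carbon with a double bond to nitrogen. In a functional assay on DLD-1 cells (Homo sapiens) for cytotoxicity, read by MTT assay, with a stated time of 72 h (a lower number here means a stronger inhibitor, a higher number a weaker inhibitor), compound 1 gives 977000000 nM and compound 2 gives 832000000 nM. The step of a 1.2-fold lower number from compound 1 to compound 2 (0.07 log units; within the scatter) stays within the scatter, so the two cannot be told apart. For the measured compounds named here, on the numbers so far compound 2 stands at the lowest of the two values, with compound 1 nearest and within the scatter.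

Compound 3 `COc1ccc(/C=N/c2c(C)n(C)n(-c3ccccc3)c2=O)cc1OC` is not yet measured in this assay. Relative to compound 2 the change is methoxy in place of hydrogen on an aromatic carbon. Going by the values given here, the one measured step that bears on it, a 1.2-fold lower number from compound 1 to compound 2 (0.07 log units; within the scatter), moved a methoxy group around the same ring and gave nothing beyond the scatter, so the basis for any shift in this assay from a second methoxy group is thin. The expected step is therefore none beyond the scatter, a 1.0-fold higher number from compound 2 to compound 3 (0.01 log units; within the scatter). Compound 3 is estimated at 850000000 nM in this assay, with a range from 400000000 nM to 1800000000 nM.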

Compound 3, half-maximal inhibitory concentration: 676000000 nM
Estimate against measurement, compound 3: 1.3-fold (0.10 log units) above; the measured number falls inside the stated range.
By their numbers in this assay, from the lowest: compounds 3, 2 and 1 (each within the scatter of the next).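

Methoxy in place of hydrogen on an aromatic carbon, ortho to a methoxy group and para to a large group, gives in this assay a 1.2-fold lower number from compound 2 to compound 3 (0.09 log units; within the scatter), and the same comparison made against the other single-methoxy compound gives a 1.4-fold lower number from compound 1 to compound 3 (0.16 log units; within the scatter). For the compounds shown here, the earlier pair showed only that a methoxy group could be moved around this ring without a readable difference; these two steps show that a second methoxy group at this position also leaves the compounds indistinguishable, whichever single-methoxy compound serves as the reference. No separate data on these compounds bear on why the numbers fall as they do.

What the compounds shown leave open is whether any substituent on this ring can move the number beyond the scatter, since methoxy is the only group represented here, and an amine, a carboxylic acid or a halogen such as chlorine could behave differently at the same carbon. Also open, as far as these compounds go, is whether changes elsewhere, on the phenyl group or the methyl groups of the shared core, would separate compounds that this ring position does not.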